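The source may hold more compounds than are shown below. What is called first, only, known or untested is meant among the compounds shown, and "the series" means these compounds.

Measured so far in a functional assay on CCRF-CEM cells (Homo sapiens) for cytotoxicity, read by MTT assay, with a stated time of 72 h; a lower number here means a stronger inhibitor of growth, a higher number a weaker inhibitor of growth:
compound 1, `CCOC(=O)Nc1ccc([Se][Se]c2ccc(NC(=O)OCC)cc2)cc1`, gives 24600 nM
compound 2, `CC(C)COC(=O)Nc1ccc([Se]C#N)cc1`, gives 9300 nM
compound 3, `CCCCCCOC(=O)Nc1ccc([Se][Se]c2ccc(NC(=O)OCCCCCC)cc2)cc1`, gives 6200 nM

Compound 2 holds the second-highest number of the three; it lies within the scatter of compound 3 and beyond the scatter from compound 1, which shows the higher number. Compound 4, `CCOC(=O)Nc1ccc([Se]C#N)cc1`, is not yet measured. It differs from compound 2 by methyl in place of isopropyl on a saturated chain carbon bound to an oxygen next to a carbonyl group. Among the measured compounds shown here, no step between measured compounds covers this change. Compound 1 and compound 3 share one core and differ only in the chain on the oxygen next to the carbonyl group, compound 3 with the longer chain showing the lower number. On that basis the shortening in compound 4 is expected to raise the number in this assay modestly; the expected step is a 1.6-fold higher number from compound 2 to compound 4 (0.21 log units; within the scatter). Compound 4 is estimated at 15000 nM, range 6000 nM to 40000 nM.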

Compound 4, concentration for 50% growth inhibition: 9800 nM
Estimate against measurement, compound 4: 1.5-fold (0.18 log units) above, within the range that was stated.
By their numbers in this assay, from the lowest: compounds 3, 2 and 4 (each within the scatter of the next); then compound 1.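

In this assay, the change from isobutoxy to ethoxy on the core shared by compound 2 and compound 4 gives a 1.1-fold higher number from compound 2 to compound 4 (0.02 log units; within the scatter), so methyl in place of isopropyl at this place leaves the number within the scatter. The gap between the values of compound 1 and compound 3, which carry a different core, does not appear between these two chains on this core. No measured evidence bears on why this step is so small. From the compounds shown here alone, whether a longer chain or a chain ending in an amine on this core would move the number beyond the scatter stays open.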